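Ethoxy in Place of Chloro on the Phenyl Ring

The source may report more compounds than this note shows. Statements on the series, on what has been measured and on what is new or still open speak of the compounds shown alone.

Compound 1 `Cc1cc2nc(CSC(=S)N3CCCCC3)[nH]c2cc1C`: 9550 nM
Compound 2 `COc1ccc(N2CCN(C(=S)SCc3nc4cc(C)c(C)cc4[nH]3)CC2)cc1`: 46000 nM
Compound 3 `Cc1cc2nc(CSC(=S)N3CCN(c4ccccc4Cl)CC3)[nH]c2cc1C`: 8390 nM

All three compounds share one core and were tested in a functional assay on MCF7 cells (Homo sapiens) for cytotoxicity, read by MTT assay, with a stated time of 24 h; a higher number here means a weaker inhibitor, a lower number a stronger inhibitor. Compound 3 gives the lowest of the three numbers, but compound 1 sits within the scatter of it, so the two cannot be ranked. Going by the values given here, compound 2 lies clearly apart: the step of a 5.5-fold lower number from compound 2 to compound 3 (0.74 log units; beyond the scatter) is the only change among the measured compounds that goes beyond the scatter, and it exchanges one group on the phenyl ring for another at a different place on that ring.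

Compound 4 `CCOc1ccccc1N1CCN(C(=S)SCc2nc3cc(C)c(C)cc3[nH]2)CC1` has not yet been measured in this assay. It differs from compound 3 in one place: ethoxy in place of chloro on an aromatic carbon. Among the compounds with values here, no measured step matches this change exactly. The step from compound 2 to compound 3 bears on it only loosely, since compound 2 carries a methoxy group, which resembles ethoxy, and compound 2 has the weakest number of the three. On that basis a modest rise in number is expected for compound 4, near the edge of the scatter: a 1.8-fold higher number from compound 3 to compound 4 (0.25 log units; within the scatter). The estimate for compound 4 is 15000 nM, with a range from 5000 nM to 45000 nM.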

Compound 4, half-maximal inhibitory concentration: 5580 nM
Compound 4: middle estimate off by 2.7-fold (0.43 log units), on the high side; the measured number falls inside the stated range.
By their numbers in this assay, from the lowest: compounds 4, 3 and 1 (each within the scatter of the next); then compound 2.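

On this aromatic carbon, ortho to a large group, chloro and ethoxy cannot be told apart in this assay: the exchange gives a 1.5-fold lower number from compound 3 to compound 4 (0.18 log units; within the scatter), even though ethoxy brings 3 heavy atoms in place of 1, along with a hydrogen-bond acceptor. An oxygen on the phenyl ring therefore does not by itself produce the high number of compound 2, since 2-ethoxyphenyl in place of 4-methoxyphenyl gives an 8.2-fold lower number from compound 2 to compound 4 (0.92 log units; beyond the scatter) and so remains clearly apart. No evidence is available on why these numbers fall as they do.

That step changes both the group and its place on the ring, so the compounds shown leave open whether the gap belongs to the place, to methoxy against ethoxy, or to both. They also leave open how far this aromatic carbon accepts other kinds of group, such as an amine, a carboxylic acid or a longer alkoxy chain, as each could move the number in either direction.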